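The source may hold more compounds than are shown below. What is called first, only, known or untested is meant among the compounds shown, and "the series" means these compounds.

Among the compounds with values here, compound 1 `O=c1ccc(-c2ccc3cn[nH]c3c2)cn1Cc1ccc(Cl)c(Cl)c1` is the one compound here with a measured number in an assay for inhibition of MAP kinase-interacting serine/threonine-protein kinase 2 (Homo sapiens), read by luminescence and ADP-Glo, with a stated time of 2 h (a higher number here means a weaker inhibitor, a lower number a stronger inhibitor), where compound 1 gives 97 nM. Compound 2 `O=c1ccc(-c2ccc3cc[nH]c3c2)cn1Cc1ccccc1` reaches only a limit of the assay: in this assay compound 2 gives > 2000 nM, which is a limit and not a number. Of the two values shown, one sits at the limit of > 2000 nM in this assay, at which 1 of the 2 values shown sits, so compound 1 stands alone as the sole quantified point.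

Compound 3 `Cn1cc(-c2ccc3cn[nH]c3c2)ccc1=O` has not yet been measured in this assay. It differs from compound 1 in one place: hydrogen in place of 3,4-dichlorophenyl on a saturated chain carbon bound to an aromatic nitrogen. Within the data shown here, no step between two measured compounds is available to set the scale of this change. The account therefore expects the step of a 31-fold higher number from compound 1 to compound 3 (1.49 log units; beyond the scatter) to be large and toward weaker inhibition, well beyond the usual scatter. For compound 3 the expected value in this assay is 3000 nM, with a range from 600 nM to 20000 nM.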

Compound 3, half-maximal inhibitory concentration: > 2000 nM
Compound 3: a limit, no number (the forecaster's own chance of this, stated with the estimate: 55%); the middle value does not contradict the limit.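

In this assay compound 3 gives > 2000 nM, which is a limit of the assay and not a number. Hydrogen in place of 3,4-dichlorophenyl on a saturated chain carbon bound to an aromatic nitrogen gives an at least 20-fold higher number from compound 1 to compound 3 (1.31 log units; beyond the scatter), so this is the first place shown where a single change takes away most of the measurable inhibition of compound 1. The step has a floor but no upper end, and the read-out gives no true size for it: the limit of > 2000 nM in this assay, at which 2 of the 3 values shown sit.

The compounds shown leave open whether the chlorine atoms or the aromatic ring itself carry this effect. They also leave open whether a cyclohexyl group or a pyridine ring in that place would keep inhibition close to that of compound 1.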